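Thiophene attachment point swap on the shared core

A few compounds are considered here, and "the series" means these few. Any claim that something is new, unique, unknown or untested is made for them only; others in the source may bear on it.

Compound 1 `Oc1cccc(-c2cc(-c3cccs3)cc(-c3cccc(O)c3)n2)c1` gives 1690 nM in a functional assay on HeLa cells (Homo sapiens) for cytotoxicity, read by CCK-8 assay; a lower number here means a stronger inhibitor, a higher number a weaker inhibitor. Compound 2 `Oc1ccc(-c2cc(-c3cccs3)cc(-c3cccc(O)c3)n2)cc1` gives 4140 nM in this assay and so stands highest of the two numbers, with compound 1 nearest at a 2.4-fold higher number from compound 1 to compound 2 (0.39 log units; beyond the scatter). Compound 3 `Oc1ccc(-c2cc(-c3cccs3)cc(-c3ccc(O)cc3)n2)cc1` reports only a limit in this assay, > 50000 nM. The step of an at least 12-fold higher number from compound 2 to compound 3 (1.08 log units; beyond the scatter) therefore runs into (the limit of > 50000 nM in this assay, at which 1 of the 3 values shown sits).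

Compound 4 `Oc1ccc(-c2cc(-c3ccsc3)cc(-c3cccc(O)c3)n2)cc1` differs from compound 2 by thiophen-3-yl in place of thiophen-2-yl on an aromatic carbon. Both measured steps change the hydroxyphenyl pattern and leave the thiophene untouched, so neither bears directly on this change, and the two hydroxyphenyl groups of compound 2 are retained. The expectation is thus a step of a 1.1-fold higher number from compound 2 to compound 4 (0.04 log units; within the scatter), within the scatter, in this assay. Compound 4 is accordingly estimated at 4500 nM, between 1500 nM and 15000 nM.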

Compound 4, half-maximal inhibitory concentration: 2580 nM
Compound 4: the middle estimate sits 1.7-fold (0.24 log units) above what was measured; the range from low to high includes it.
By their numbers in this assay, from the lowest: compounds 1, 4 and 2 (each within the scatter of the next, the first and the last beyond it). At a limit, above all of these: compound 3.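

Among these compounds, the swap to thiophen-3-yl gives a 1.6-fold lower number from compound 2 to compound 4 (0.21 log units; within the scatter) in this assay and so no real change at this position opposite the ring nitrogen, where the earlier steps left the thiophene untouched. With the 3-hydroxyphenyl and 4-hydroxyphenyl groups held, the two thiophene attachments are not told apart in this read-out. No measured property shown here bears on this result.

On these data alone, whether this position accepts anything other than a thiophene stays open, for instance an amine, a carboxylic acid or a plain phenyl ring. Also open, as far as these compounds go, is whether thiophen-3-yl reads the same with the two 3-hydroxyphenyl groups of compound 1.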